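Adding a Hydroxy Group to Compound 1

The source may report more compounds than this note shows. Statements on the series, on what has been measured and on what is new or still open speak of the compounds shown alone.

- compound 1 (`Cc1nc2cnccc2n1CC1CCN(C(=O)CC(C)c2ccccc2)CC1`): 12 nM
- compound 2 (`Cc1nc2cnccc2n1CC1CCN(S(=O)(=O)CC(C)(C)c2ccccc2)CC1`): 6.2 nM
- compound 3 (`CC/C(=C\C(=O)N1CCC(Cn2c(C)nc3cnccc32)CC1)c1ccccc1`): 13 nM

In a functional assay (plasma) with Oryctolagus cuniculus as the target (on this read-out lower numbers stand for stronger inhibition and higher numbers for weaker inhibition), compound 1 gives 12 nM. This number lies within the scatter of both other measured compounds, so the data do not separate compound 1 from either of them. Compound 3 is its nearest neighbour and compound 2 the furthest, and neither gap exceeds the scatter.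

Compound 4 (`Cc1nc2cnccc2n1CC1CCN(C(=O)CC(C)(O)c2ccccc2)CC1`) has not yet been measured. It keeps the shared core of compound 1 and carries hydroxy in place of hydrogen on a saturated chain carbon bound to an aromatic carbon and two saturated chain carbons.

For the measured compounds named here, no measured pair differs in a single place, so this assay offers no direct precedent for this change. Going by the values given here, the only guide is that the side chains differ among the measured compounds, yet compound 2 at 6.2 nM and compound 3 at 13 nM both stay close to compound 1. A modest move towards a higher number, meaning weaker inhibition, is therefore expected, little beyond the scatter. The expected change is a 1.7-fold higher number from compound 1 to compound 4 (0.22 log units; within the scatter). For compound 4 the estimated value is 20 nM, with an expected range from 6 nM to 70 nM.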

Compound 4, half-maximal inhibitory concentration: 6.9 nM
The estimate for compound 4 lay 2.9-fold (0.46 log units) above the measured number; measured number inside the range.
By their numbers in this assay, from the lowest: compounds 2, 4, 1 and 3 (each within the scatter of the next, the first and the last beyond it).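

In this assay, the change from 1-phenylethyl to 1-hydroxy-1-phenylethyl gives a 1.7-fold lower number from compound 1 to compound 4 (0.24 log units; within the scatter), the only step shown that differs in one place and so the first direct reading at this saturated chain carbon. The step lies within the scatter, so the numbers do not separate compound 4 from compound 1, and this position carries a hydroxy group in place of hydrogen without a difference that this read-out can resolve. No measurement at hand bears on why the two compounds read alike, or on what the hydroxy group does at this carbon.

As far as these compounds go, what remains open is whether other groups on this same carbon, such as a methoxy group, a fluorine atom or an amine, would also stay within the scatter of compound 1. From the compounds shown here alone, it is equally open whether something larger there, such as a carboxylic acid or a longer chain, would give a step beyond the scatter in either direction.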